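This account rests on a few compounds, and the source may have more. Where it says the series, first, only, none or still open, it means among the compounds named here.

Of the compounds shown here, three sharing one core have been measured in a functional assay on Ehrlich cells (Mus musculus) for cytotoxicity, read by MTT assay, with a stated time of 48 h; a higher number here means a weaker inhibitor, a lower number a stronger inhibitor. Compound 1 `O=C(COc1ccc(Cl)cc1)Nc1nc(-c2ccc(Br)cc2)cs1` gives 40100 nM. Compound 2 `O=C(COc1ccc(Cl)cc1)Nc1nc(-c2ccc(Cl)cc2)cs1` gives 51900 nM, and compound 3 `O=C(COc1ccc(F)cc1F)Nc1nc(-c2ccc(Br)cc2)cs1` gives 44200 nM. Compound 2 holds the highest of the three numbers, but the step of a 1.3-fold higher number from compound 1 to compound 2 (0.11 log units; within the scatter) lies within the scatter, and the values of compound 2 and compound 3 are likewise within the scatter of each other, so the three cannot be separated on these data.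

The step now followed leads from compound 2 to compound 4 `Cc1ccc(OCC(=O)Nc2nc(-c3ccc(Cl)cc3)cs2)cc1`. The change is methyl in place of chloro on an aromatic carbon. Among the measured compounds shown here, two measured steps bear on it: the step of a 1.1-fold higher number from compound 1 to compound 3 (0.04 log units; within the scatter) altered the same phenoxy ring, from 4-chlorophenyl to 2,4-difluorophenyl, without a step beyond the scatter, and the step of a 1.3-fold higher number from compound 1 to compound 2 (0.11 log units; within the scatter) exchanged one halogen for another on the other aryl ring with the same outcome. Neither points to a movement beyond the scatter, in either direction. The expected step is a 1.0-fold lower number from compound 2 to compound 4 (0.02 log units; within the scatter). Compound 4 is therefore estimated to give 50000 nM, within a range from 25000 nM to 100000 nM.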

Compound 4, half-maximal inhibitory concentration: 40600 nM
The estimate for compound 4 lay 1.2-fold (0.09 log units) above the measured number; measured number inside the range.
By their numbers in this assay, from the lowest: compounds 1, 4, 3 and 2 (each within the scatter of the next).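

In this assay, among the compounds shown here, the change from 4-chlorophenoxy to 4-methylphenoxy gives a 1.3-fold lower number from compound 2 to compound 4 (0.11 log units; within the scatter) and so extends the picture at this position beyond halogens, the only substituents on this ring in the earlier compounds. A methyl group, which is carbon rather than halogen, can thus stand on this aromatic carbon, para to a large group, without a step beyond the scatter. No measured evidence is available that would explain this result.

The compounds shown leave open whether any group at this position can move the number beyond the scatter, since a methyl and the halogens are all that can be compared here. An amine, a carboxylic acid or a longer chain such as butyl in this place could still answer that question, and the same holds for the bromo and chloro position on the other aryl ring.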